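The source may report more compounds than this note shows. Statements on the series, on what has been measured and on what is new or still open speak of the compounds shown alone.

Measured compounds:

Compound 1, `CC(=O)Nc1ccc(-c2nc3cc(C(F)(F)F)ccc3n2C)cc1`: 46000 nM
Compound 2, `CC(=O)Nc1ccc(-c2nc3cc(C(F)(F)F)ccc3[nH]2)cc1`: 50000 nM
Compound 3, `Cn1c(-c2ccc(NC(=O)CN3CCN(c4ccccc4)CC3)cc2)nc2cc(C(F)(F)F)ccc21`: 1400 nM

All three were run in an ADME assay on MDBK cells (Bos taurus) for cytotoxicity, read by MTT assay, with a stated time of 96 h; on this read-out higher numbers stand for lower toxicity in this test and lower numbers for higher toxicity in this test. Compound 1 and compound 2 share a core and differ by hydrogen in place of methyl on an aromatic nitrogen; the step of a 1.1-fold higher number from compound 1 to compound 2 (0.04 log units; within the scatter) shows that this exchange leaves the read-out essentially unchanged. Compound 3 carries the core of compound 1 with a further difference, (4-phenylpiperazin-1-yl in place of hydrogen on a saturated chain carbon bound to a carbonyl carbon), and here the step of a 33-fold lower number from compound 1 to compound 3 (1.52 log units; beyond the scatter) is large, so compound 3 has the lowest number of the three.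

Compound 4, `O=C(CN1CCN(c2ccccc2)CC1)Nc1ccc(-c2nc3cc(C(F)(F)F)ccc3[nH]2)cc1`, has not yet been measured in this assay. Among the compounds with values here, it differs from compound 3 by hydrogen in place of methyl on an aromatic nitrogen, which is the same change as the one from compound 1 to compound 2: the place lines agree word for word. Nothing more is known about the pair compound 3 and compound 4 beyond this structural relation.

Within the data shown here, the expectation for compound 4 rests on the one earlier instance of this change, the step of a 1.1-fold higher number from compound 1 to compound 2 (0.04 log units; within the scatter), which stayed within the scatter. The step from compound 3 to compound 4 in this assay is therefore estimated as a 1.1-fold higher number from compound 3 to compound 4 (0.03 log units; within the scatter), alongside that earlier step. Among the measured compounds shown here, compound 4 is expected to give about 1500 nM in this assay, with a plausible span of 600 nM to 4000 nM, the width reflecting that only a single prior example of this change exists and that the core difference between compound 1 and compound 3 is large. The measured value will show whether this expectation holds.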

Compound 4, half-maximal cytotoxic concentration: 32000 nM
The estimate for compound 4 lay 21-fold (1.33 log units) below the measured number; the whole stated range lies below it.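

On the core of compound 3, hydrogen in place of methyl on an aromatic nitrogen gives a clear shift in this assay (a 23-fold higher number from compound 3 to compound 4 (1.36 log units; beyond the scatter)), towards lower toxicity in this test. The exchange therefore does not carry over as a fixed step from one core to the other: the same change on two cores in this assay, a 1.1-fold higher number (0.04 log units; within the scatter) from compound 1 to compound 2 and a 23-fold higher number (1.36 log units; beyond the scatter) from compound 3 to compound 4, 21-fold (1.32 log units) apart, beyond the scatter of two such steps. In these two pairs the size of the step goes with the core that bears it, but two pairs give no rule for other cores, and the numbers do not show why the step differs or which part of the 4-phenylpiperazin-1-yl group matters.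

The compounds shown leave open whether the large step needs the whole 4-phenylpiperazin-1-yl group or only a basic amine on that chain carbon; a piperazine without the phenyl ring, a morpholine or a dimethylamino group, each paired with and without the methyl on the aromatic nitrogen, would separate these cases. Also open, on these data alone, is whether an ethyl group or a longer alkyl chain on that aromatic nitrogen would track the methyl compounds or the hydrogen compounds on either core.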